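From Fluoro to Amino on the Aryl Group

A few compounds are considered here, and "the series" means these few. Any claim that something is new, unique, unknown or untested is made for them only; others in the source may bear on it.

Measured in a functional assay on SGC-7901 cells (Homo sapiens) for antiproliferative activity, read by MTT assay, with a stated time of 72 h; on this read-out lower numbers stand for stronger inhibition and higher numbers for weaker inhibition:
- Compound 1 `COc1cc(-n2cnc3ccc(-c4ccccc4Cl)cc32)cc(OC)c1OC`: > 10000 nM, a limit of the assay and not a number
- Compound 2 `COc1cc(-n2cnc3ccc(-c4ccc([N+](=O)[O-])cc4)cc32)cc(OC)c1OC`: 79 nM
- Compound 3 `COc1cc(-n2cnc3ccc(-c4cccc(F)c4)cc32)cc(OC)c1OC`: 2490 nM

Of the two exact numbers, the higher belongs to compound 3. The gap is a 32-fold higher number from compound 2 to compound 3 (1.50 log units; beyond the scatter).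

Compound 4 `COc1cc(-n2cnc3ccc(-c4cccc(N)c4)cc32)cc(OC)c1OC` has amino in place of fluoro on an aromatic carbon. Within the data shown here, no measured step makes this exchange. The closest guides are two other aryl changes, an at least 4.0-fold lower number from compound 1 to compound 3 (0.60 log units; beyond the scatter) and an at least 120-fold lower number from compound 1 to compound 2 (2.10 log units; beyond the scatter), which show how far such changes can move the number. A moderate step to a lower number is therefore expected in this assay, with wide uncertainty. The expected step is a 3.1-fold lower number from compound 3 to compound 4 (0.49 log units; beyond the scatter). Compound 4 is estimated at 800 nM, with an expected range of 100 nM to 6000 nM.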

Compound 4, half-maximal inhibitory concentration: 21 nM
Compound 4: the middle estimate sits 38-fold (1.58 log units) above what was measured, and the stated range ends above it.
By their numbers in this assay, from the lowest: compound 4; then compound 2; then compound 3. At a limit, above all of these: compound 1.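

In this assay the change of fluoro to amino at this place alone gives a 120-fold lower number from compound 3 to compound 4 (2.07 log units; beyond the scatter), so one group here moves the number as far as the whole aryl changes did. The 3-aminophenyl group also gives a 3.8-fold lower number from compound 2 to compound 4 (0.58 log units; beyond the scatter), so the lowest number shown does not depend on 4-nitrophenyl. The remaining step, an at least 470-fold lower number from compound 1 to compound 4 (2.67 log units; beyond the scatter), is only a bound, since its starting value is a limit of the assay: the limit of > 10000 nM in this assay, at which 1 of the 4 values shown sits.

The compounds shown leave open whether the low number is particular to amino. A hydroxyl, a methylamino or an acetamide at this place could tell, and so could amino on another carbon of the ring.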